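Hydroxyphenyl Swaps on a Shared Core and Topoisomerase Inhibition

This account rests on a few compounds, and the source may have more. Where it says the series, first, only, none or still open, it means among the compounds named here.

Measured in an assay on isolated protein for inhibition of DNA topoisomerase 1 (Homo sapiens), with a stated time of 30 min, tested at 100 uM; a higher number here means more inhibition at the concentration tested (going by the name of the read-out), a lower number less inhibition:
compound 1 `Oc1cccc(-c2cc(-c3cccc(O)c3)nc(-c3ccccc3O)c2)c1` gives 1.9%
compound 2 `Oc1ccc(-c2cc(-c3cccc(O)c3)cc(-c3cccc(O)c3)n2)cc1` gives 0%
compound 3 `Oc1ccc(-c2cc(-c3cccc(O)c3)cc(-c3ccccc3O)n2)cc1` gives 8.4%

Compound 3 has the highest of these three numbers, yet both a number 6.5 percentage points higher from compound 1 to compound 3 (within the scatter) and a number 8.4 percentage points higher from compound 2 to compound 3 (within the scatter) lie within the scatter, so no ordering among the three can be claimed. Compound 4 `Oc1ccc(-c2cc(-c3ccc(O)cc3)nc(-c3ccccc3O)c2)cc1` is the next compound. It differs from compound 3 as follows: 4-hydroxyphenyl in place of 3-hydroxyphenyl on an aromatic carbon. Among the compounds with values here, the one measured step of the same kind is a number 6.5 percentage points higher from compound 1 to compound 3 (within the scatter), within the scatter, and the remaining step of a number 1.9 percentage points lower from compound 1 to compound 2 (within the scatter) is also within the scatter. The expected change in this assay is therefore a number 3.4 percentage points lower from compound 3 to compound 4 (within the scatter), nothing beyond the scatter. Compound 4 is estimated at 5%, with a range from 0% to 15%.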

Compound 4, a percentage reported as inhibition, at one concentration (the size of the read-out at that concentration, not a potency): 0%
Compound 4: the middle estimate sits 5 percentage points above what was measured; low and high end bracket the measured number.
By their numbers in this assay, from the lowest: compounds 2, 4, 1 and 3 (each within the scatter of the next).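

At this carbon opposite the ring nitrogen, with a 2-hydroxyphenyl group on the shared core, 4-hydroxyphenyl in place of 3-hydroxyphenyl gives a number 8.4 percentage points lower from compound 3 to compound 4 (within the scatter) in this assay. With a number 6.5 percentage points higher from compound 1 to compound 3 (within the scatter) as well, both steps of this kind now stay within the scatter, so this swap shows no effect that can be told from repeat noise. No measurement shown offers an explanation for these numbers.

As far as these compounds go, whether any group at this carbon can lift the number beyond the scatter stays open. A phenyl ring carrying a methoxy group, an amine or a carboxylic acid in place of the hydroxyl would test this.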